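This account rests on a few compounds, and the source may have more. Where it says the series, first, only, none or still open, it means among the compounds named here.

Measured so far:
Compound 1 `COc1ccc(NC(=O)Nc2n[nH]c3ccccc23)cc1` in a functional assay on SK-MEL-2 cells (Homo sapiens) for inhibition, read by sulforhodamine B assay, with a stated time of 48 h; on this read-out higher numbers stand for weaker inhibition of growth and lower numbers for stronger inhibition of growth: > 100000 nM
Compound 2 `CCCCOc1ccc(NC(=O)n2nc(N)c3ccccc32)cc1`: "not determined" (no result reported)
Compound 3 `Nc1nn(C(=O)Nc2c(F)cccc2F)c2ccccc12`: < 100000 nM

The three compounds share a core built around an indazole joined through a urea to a substituted benzene, but they are not a tidy series: compound 1 carries the urea on the ring nitrogen with a methoxy group at the far end, compound 2 carries an amino group on the core and a butoxy group on the benzene, and compound 3 has the same amino core with two fluorines on its benzene. For compound 1 the reported value is a limit, not a number, namely (the limit of > 100000 nM in this assay, at which 1 of the 3 values shown sits). For compound 3 the reported value is also a limit, (the limit of < 100000 nM in this assay, at which 1 of the 3 values shown sits). Compound 2 itself has no result in this assay , so it cannot be placed among the numbers at all; what can be said is that its neighbours give only limits on either side.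

Compound 4 `Nc1nn(C(=O)Nc2ccc(Cc3ccccc3)cc2)c2ccccc12` differs from compound 2 by a single change, (benzyl in place of butoxy on an aromatic carbon). With no measured step between any two of these compounds, no size or direction of change in this assay can be read off; the step could be anything from nothing beyond the scatter to large. On that thin footing, compound 4 is expected to give about 30000 nM, most likely between 3000 nM and 200000 nM.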

Compound 4, concentration for 50% growth inhibition: 36400 nM
Compound 4: middle estimate off by 1.2-fold (0.08 log units), on the low side, within the range that was stated.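

In this assay compound 4 gives 36400 nM, but compound 2 has no number to set beside it, so the change between compound 2 and compound 4 cannot be read as a step. The compounds shown leave open how much putting benzyl in place of butoxy alters the result in this assay.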